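This account rests on a few compounds, and the source may have more. Where it says the series, first, only, none or still open, it means among the compounds named here.

Three compounds have been measured so far in a physicochemical assay for solubility, in phosphate buffer; on this read-out lower numbers stand for lower solubility and higher numbers for higher solubility

Compound 1 (`C[C@H]1CN([C@@H](C)CO)C(=O)c2cccc(NC(=O)c3ccncc3)c2O[C@@H]1CN(C)Cc1ccc(Cl)c(Cl)c1`) gives 64000 nM
Compound 2 (`C[C@@H]1CN([C@H](C)CO)C(=O)c2cccc(NC(=O)c3ccncc3)c2O[C@@H]1CN(C)Cc1ccc(Oc2ccccc2)cc1`) gives 86000 nM
Compound 3 (`C[C@H]1CN([C@@H](C)CO)C(=O)c2cccc(NC(=O)c3ccncc3)c2O[C@@H]1CN(C)Cc1ccccc1`) gives 100000 nM

Compound 2, at 86000 nM in this read-out, lies within the usual scatter of both compound 1 and compound 3, so these numbers cannot tell the three apart.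

Compound 4 (`C[C@@H]1CN([C@@H](C)CO)C(=O)c2cccc(NC(=O)c3ccncc3)c2O[C@H]1CN(C)Cc1ccc(Oc2ccccc2)cc1`) has not been measured yet. Its difference from compound 2 is the two compounds have the same atoms and bonds and differ only in configuration as drawn: 2 of 3 stereo elements differ; a stereocentre at a saturated chain carbon is drawn R in compound 2 and S in compound 4; a stereocentre at a saturated ring carbon is drawn S in compound 2 and R in compound 4 and the two compounds have the same atoms and bonds. A stereocentre at a saturated chain carbon is drawn R in compound 2 and S in compound 4, and a stereocentre at a saturated ring carbon is drawn S in compound 2 and R in compound 4.

Within the data shown here, the only measured step between compounds that differ in one place is a 1.6-fold higher number from compound 1 to compound 3 (0.19 log units; within the scatter) with phenyl in place of 3,4-dichlorophenyl. Among the measured compounds shown here, that step lies within the scatter and involves no change of configuration, so no measured step tests this kind of change directly. The data therefore give no reason to expect a shift in this assay in either direction. The expected change is an estimated 1.1-fold lower number from compound 2 to compound 4 (0.03 log units; within the scatter) and so nothing beyond the scatter. Compound 4 is estimated at 80000 nM (expected range 40000 nM to 140000 nM).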

Compound 4, solubility: 1000 nM
Estimate against measurement, compound 4: 80-fold (1.90 log units) above; the whole stated range lies above it.
By their numbers in this assay, from the lowest: compound 4; then compounds 1, 2 and 3 (each within the scatter of the next).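

In this assay, among these compounds, a change of configuration alone gives an 86-fold lower number from compound 2 to compound 4 (1.93 log units; beyond the scatter), and this is the first step that lies beyond the scatter. Among the compounds shown here, the only earlier step, a 1.6-fold higher number from compound 1 to compound 3 (0.19 log units; within the scatter), replaced one group on the saturated chain carbon bound to the amine nitrogen and showed no shift that could be told from the scatter, so it gave no sign that the number could move this far. The large step can be traced to the spatial arrangement of the molecule rather than to any change of atoms or bonds, because of one plain point: the fact that compounds 2 and 4 differ only in the configuration as drawn

Which of the two stereocentres carries the step stays open, as they change together in this pair and the compounds shown do not separate them. Also open, going by these compounds, is whether this configuration gives a similarly low number with phenyl or 3,4-dichlorophenyl, or with a different group such as a carboxylic acid, on that same saturated chain carbon.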